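This account rests on a few compounds, and the source may have more. Where it says the series, first, only, none or still open, it means among the compounds named here.

Three thiosemicarbazone-type compounds built on a shared core have been measured for their effect on A-431 cell viability. Compound 1 `N/C(=N\NC(=S)N1CCOCC1)c1ccccn1` gives 4800 nM in a functional assay on A-431 cells (Homo sapiens) for cytotoxicity, read by MTT assay, with a stated time of 72 h; on this read-out higher numbers stand for weaker inhibition and lower numbers for stronger inhibition. Compound 2 `Cc1cccc(/C(N)=N/NC(=S)N2CCSCC2)n1` gives 2600 nM in this assay, and compound 3 `Cc1ccnc(/C(N)=N/NC(=S)N2CCSCC2)c1` gives 7200 nM. Compound 3 thus shows the highest of the three numbers: its gap to compound 1 lies within the scatter of repeated measurements, while its gap to compound 2 lies beyond it.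

The next compound in the series, compound 4 `N/C(=N\NC(=S)N1CCSCC1)c1ccccn1`, has not yet been measured in this assay. It differs from compound 3 by hydrogen in place of methyl on an aromatic carbon, the methyl being removed from an aromatic carbon of a six-membered aromatic ring with one nitrogen, meta to a large group and opposite the ring nitrogen.

Within the data shown here, no directly comparable step between measured compounds is available for this change. Given that compound 1, which also carries no methyl, gives 4800 nM, a step toward a somewhat lower number is expected, likely within the scatter, so that compound 4 is expected to give 3800 nM in this assay, between 1600 nM and 9000 nM, corresponding to an estimated step of a 1.9-fold lower number from compound 3 to compound 4 (0.28 log units; within the scatter).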

Compound 4, half-maximal inhibitory concentration: 6700 nM
Estimate against measurement, compound 4: 1.8-fold (0.25 log units) below; measured number inside the range.
By their numbers in this assay, from the lowest: compounds 2, 1, 4 and 3 (each within the scatter of the next, the first and the last beyond it).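

Taking the methyl off the aromatic carbon opposite the ring nitrogen gives a 1.1-fold lower number from compound 3 to compound 4 (0.03 log units; within the scatter), so at this position the group makes no readable difference. The same exchange read against compound 2, whose methyl stands on a different ring carbon, gives a 2.6-fold higher number from compound 2 to compound 4 (0.41 log units; beyond the scatter), the only one of these steps beyond the scatter, so among these compounds the outcome depends on where the methyl stands. Thiomorpholin-4-yl in place of morpholin-4-yl on the thiocarbonyl carbon gives a 1.4-fold higher number from compound 1 to compound 4 (0.14 log units; within the scatter), so that exchange is not resolved either.

As far as these compounds go, whether an amine, a methoxy group or a chlorine at the position opposite the ring nitrogen would move the number remains open, as does whether the methyl of compound 2 would count the same with morpholin-4-yl in place of thiomorpholin-4-yl. Nothing available explains why one methyl counts here and the other does not.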